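This account rests on a few compounds, and the source may have more. Where it says the series, first, only, none or still open, it means among the compounds named here.

Measured so far in a functional assay on G-361 cells (Homo sapiens) for antiproliferative activity, with a stated time of 72 h; a higher number here means a weaker inhibitor, a lower number a stronger inhibitor:
- compound 1 `OC[C@H]1O[C@@H](n2cnc3c(NCc4ccccc4F)ncnc32)[C@H](O)[C@@H]1O`: "not determined" (no result reported)
- compound 2 `Cc1cccc(CNc2ncnc3c2ncn3[C@@H]2O[C@H](CO)[C@@H](O)[C@H]2O)c1`: > 166000 nM

Only compound 2 has a reading, and that reading is a limit of the assay rather than a true number. Its position can be summed up as the limit of > 166000 nM in this assay, at which 1 of the 2 values shown sits. Compound 1 has no reported result, so it offers no comparison.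

Compound 3 `OC[C@H]1O[C@@H](n2cnc3c(NCc4ccc(Cl)cc4Cl)ncnc32)[C@H](O)[C@@H]1O` has not yet been measured. It differs from compound 2 in one place, on a saturated chain carbon bound to a nitrogen on an aromatic ring, where 2,4-dichlorophenyl stands in place of 3-methylphenyl: 2,4-dichlorophenyl in place of 3-methylphenyl on a saturated chain carbon bound to a nitrogen on an aromatic ring.

Among the measured compounds shown here, no measured step shows what such a swap does in this assay, so any expectation here is loose. The limit of compound 2, > 166000 nM, leaves room in one direction only, towards stronger inhibition. A modest move in that direction is expected, although another result reported only as a limit would be no surprise. The expected change is an at least 2.7-fold lower number from compound 2 to compound 3 (0.44 log units; beyond the scatter). Compound 3 is estimated at 60000 nM, with an expected range from 10000 nM to 166000 nM.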

Compound 3, half-maximal inhibitory concentration: 128000 nM
Compound 3: the middle estimate sits 2.1-fold (0.33 log units) below what was measured; measured number inside the range.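

In this assay, among the compounds shown here, compound 3 gives the first reading on this series that is an actual number rather than a limit, which shows that a group at this position, on a saturated chain carbon bound to a nitrogen on an aromatic ring, can bring the result within the measurable range. Replacing 3-methylbenzyl with 2,4-dichlorobenzyl gives an at least 1.2-fold lower number from compound 2 to compound 3 (0.11 log units; that floor lies within the scatter), so the true change may be larger, but the printed floor alone does not establish a real change in potency. The step has no upper bound and can be stated only as a floor because the reading for compound 2 is a limit: the limit of > 166000 nM in this assay, at which 1 of the 3 values shown sits.

This single swap removes a methyl group and adds two chlorine atoms at once, so the compounds shown cannot separate the contribution of either chlorine atom from the loss of the methyl group. Also open, going by these compounds, is how this position would respond to a different kind of group, such as 4-chlorophenyl, a phenyl ring carrying an amine or a carboxylic acid, or a longer chain in place of the benzyl group.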